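The compounds below may be only part of what the source reports. "The series", "measured", "known", "first", "only" and "open" are said of these compounds alone.

Of the compounds shown here, three that share one core have been measured in a functional assay, read by spectrophotometry, with a stated time of 3 min; a lower number here means a stronger inhibitor, a higher number a weaker inhibitor. Compound 1 `Nc1ccccc1/N=C\c1cc(=O)oc2cc(OCc3ccccc3)ccc12` gives 9250 nM in this assay. Compound 2 `N/N=C\c1cc(=O)oc2cc(OCc3ccccc3)ccc12` gives 9740 nM, and compound 3 `O=c1cc(/C=N\Nc2ccccc2)c2ccc(OCc3ccccc3)cc2o1` gives 13200 nM. Compound 1 has the lowest of the three numbers, yet the steps away from it are small, a 1.1-fold higher number from compound 1 to compound 2 (0.02 log units; within the scatter) and a 1.4-fold higher number from compound 1 to compound 3 (0.15 log units; within the scatter), as is the step of a 1.4-fold higher number from compound 2 to compound 3 (0.13 log units; within the scatter), so the three compounds cannot be told apart on these numbers.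

Compound 4 `Nc1ccccc1/N=C\c1cc(=O)oc2cc(OCc3ccccc3)cc(OCc3ccccc3)c12` differs from compound 1 in one place: benzyloxy in place of hydrogen on an aromatic carbon. For the measured compounds named here, each measured step changes the group on the double-bonded nitrogen, whereas this change adds a group to the core itself, so no measured step bears on it, and the numbers give no direction for the step in this assay. The expectation is therefore a number close to that of compound 1, with a wide range on both sides. For compound 4 the estimate is 9500 nM, expected to lie between 3000 nM and 30000 nM. This estimate corresponds to an expected step of a 1.0-fold higher number from compound 1 to compound 4 (0.01 log units; within the scatter).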

Compound 4, half-maximal inhibitory concentration: 7530 nM
For compound 4 the middle estimate is 1.3-fold (0.10 log units) above the measured one, and the stated range covers the measured number.
By their numbers in this assay, from the lowest: compounds 4, 1, 2 and 3 (each within the scatter of the next).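

Adding a benzyloxy group to an aromatic carbon of the shared core, ortho to a fused ring, gives a 1.2-fold lower number from compound 1 to compound 4 (0.09 log units; within the scatter) in this assay. For the compounds shown here, this is the first step that alters the core rather than the group on the double-bonded nitrogen, and it too stays within the scatter. This carbon therefore takes a benzyloxy group, with its own six-membered aromatic ring, without a difference these numbers can detect, even with a benzyloxy group already meta to it; no evidence is available on why the step is this small.

As far as these compounds go, whether methoxy, hydroxyl or an amine on this carbon would also leave the number within the scatter stays open. So does whether the added benzyloxy group would give a similar step with the amino group of compound 2 or the anilino group of compound 3 on the double-bonded nitrogen.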